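Ethoxy in Place of Fluoro: From Compound 3 to Compound 4

The source may hold more compounds than are shown below. What is called first, only, known or untested is meant among the compounds shown, and "the series" means these compounds.

The measured compounds in a functional assay on A-375 cells (Homo sapiens) for antiproliferative activity, read by MTT assay, with a stated time of 24 h, tested at 0.14 ug/mL; on this read-out higher numbers stand for a stronger effect at the one concentration tested and lower numbers for a weaker effect:
Compound 1, `CCOc1ccc2nc(C(=O)Nc3c(F)cc(-c4cccc(F)c4)cc3F)c(C)c(O)c2c1`, gives 1.54%.
Compound 2, `CCc1ccc2nc(C(=O)Nc3c(F)cc(-c4cccc(F)c4)cc3F)c(C)c(C(=O)O)c2c1`, gives 2.45%.
Compound 3, `Cc1c(C(=O)Nc2c(F)cc(-c3cccc(F)c3)cc2F)nc2ccc(F)cc2c1C(=O)O`, gives 1.05%.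

Compound 3 holds the lowest of the three numbers, yet its distance to compound 1 and to compound 2 is within the scatter, so none of the three can be set apart from the others. All three values sit close to zero at the single concentration tested.

Compound 4, `CCOc1ccc2nc(C(=O)Nc3c(F)cc(-c4cccc(F)c4)cc3F)c(C)c(C(=O)O)c2c1`, is not yet measured. It differs from compound 3 by ethoxy in place of fluoro on an aromatic carbon. Among the measured compounds shown here, one measured step bears on this change: a number 1.4 percentage points lower from compound 2 to compound 3 (within the scatter), which swaps an alkyl group for fluoro at the same place and left the read-out essentially unchanged. Compound 1, which carries the ethoxy group, shows a value no further from compound 3 than the scatter. Compound 4 is therefore expected to stay flat, with a step of a number 1 percentage points higher from compound 3 to compound 4 (within the scatter) that lies within the scatter. Compound 4 is estimated at 2%, in the range -5% to 9%.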

Compound 4, a percentage reported as inhibition, at one concentration (the size of the read-out at that concentration, not a potency): 3.05%
For compound 4 the middle estimate is 1.1 percentage points below the measured one; low and high end bracket the measured number.
By their numbers in this assay, from the lowest: compounds 3, 1, 2 and 4 (each within the scatter of the next).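

In this assay, ethoxy, ethyl and fluoro on this aromatic carbon cannot be told apart with the carboxy group in place: ethoxy in place of fluoro gives a number 2 percentage points higher from compound 3 to compound 4 (within the scatter), and ethoxy in place of ethyl gives a number 0.6 percentage points higher from compound 2 to compound 4 (within the scatter). With ethoxy held fixed, the hydroxy and carboxy compounds also cannot be told apart, as carboxy in place of hydroxy gives a number 1.5 percentage points higher from compound 1 to compound 4 (within the scatter), so neither of the two places examined here moves the read-out beyond the scatter. No measurement available here accounts for this flat picture.

The compounds shown leave open what an amine or a longer alkoxy chain on this aromatic carbon would do to the read-out. They also leave open whether an amide in place of the carboxy group would change it.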